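The compounds below may be only part of what the source reports. "The series", "measured", "known", "first", "only" and "open" are said of these compounds alone.

Compound 1 `COc1cc(-c2ccc(-c3ccc(-c4nc5cc(C)ccc5[nH]4)cc3)cc2)cc(OC)c1OC` gives 190 nM in a functional assay on ZR-75-1 cells (Homo sapiens) for inhibition, read by sulforhodamine B assay; on this read-out higher numbers stand for weaker inhibition of growth and lower numbers for stronger inhibition of growth
Compound 2 `Fc1ccc(-c2ccc(-c3ccc(-c4nc5ccccc5[nH]4)cc3)cc2)cc1` gives 100000 nM in this assay

Compound 2 holds the higher of the two numbers and lies beyond the scatter from compound 1. Compound 3 `Oc1ccc(-c2ccc(-c3ccc(-c4nc5ccccc5[nH]4)cc3)cc2)cc1` alters compound 2 in one place. The change hydroxy in place of fluoro on an aromatic carbon is hydroxy in place of fluoro on an aromatic carbon. Among the measured compounds shown here, no measured pair shows this change, so any expectation is rough. For the measured compounds named here, compound 2 stands at 100000 nM and the only other value is far lower, so the move expected in this assay is toward stronger inhibition, beyond the scatter. The expected step is an 8.3-fold lower number from compound 2 to compound 3 (0.92 log units; beyond the scatter) in size. Compound 3 is estimated at 12000 nM with an expected range from 1500 nM to 100000 nM on this read-out.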

Compound 3, concentration for 50% growth inhibition: 100000 nM
For compound 3 the middle estimate is 8.3-fold (0.92 log units) below the measured one; measured number inside the range.
By their numbers in this assay, from the lowest: compound 1; then compounds 2 and 3 (each within the scatter of the next).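

In this assay, hydroxy in place of fluoro on this aromatic carbon, para to a large group, gives no change at the digits printed from compound 2 to compound 3 (within the scatter) and so leaves the number where it stood. At this position, then, the change from 4-fluorophenyl to 4-hydroxyphenyl, which brings in a hydrogen-bond donor and a hydrogen-bond acceptor, does not by itself strengthen inhibition of growth. Nothing available accounts for this result. The compounds shown leave open whether an amine, a carboxylic acid or a methoxy group here would move the number, and whether several methoxy groups on this ring would do so on the same core.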